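The source may hold more compounds than are shown below. What is called first, only, known or untested is meant among the compounds shown, and "the series" means these compounds.

Compound 1 `CCC(Sc1nc2c(cnn2C)c(=O)n1-c1ccccc1)c1ccccc1` and compound 2 `CC(Sc1nc2c(cnn2C)c(=O)n1-c1ccccc1)c1cncnc1` share one core and differ only in the group attached to the sulfur. In an assay on isolated protein for inhibition of retinal dehydrogenase 2 (Homo sapiens) (on this read-out higher numbers stand for weaker inhibition and lower numbers for stronger inhibition), compound 1 gives 179 nM, and compound 2 gives 380 nM. Among the compounds with values here, of the two numbers measured so far, compound 2 stands highest, meaning its inhibition is the weaker of the pair, with compound 1 as its nearest neighbour. Within the data shown here, the only measured step that bears on the present change is a 2.1-fold higher number from compound 1 to compound 2 (0.33 log units; beyond the scatter), since it too alters the group on the sulfur. Compound 3 `CC(Sc1nc2c(cnn2C)c(=O)n1-c1ccccc1)c1cccnc1` is not yet measured; it differs from compound 2 in one place: pyridin-3-yl in place of pyrimidin-5-yl on a saturated chain carbon bound to a saturated chain carbon and a sulfur. Compound 3 thus keeps the ethyl chain of compound 2 while its ring sits closer to the phenyl of compound 1. Since a 2.1-fold higher number from compound 1 to compound 2 (0.33 log units; beyond the scatter) was modest, the expected change is small, if anything toward a lower number: a 1.4-fold lower number from compound 2 to compound 3 (0.13 log units; within the scatter). For compound 3 the estimated value in this assay is 280 nM, with a range of 120 nM to 650 nM.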

Compound 3, half-maximal inhibitory concentration in the retinal dehydrogenase 2 assay: 89 nM
Beside the measured number, compound 3's estimate is 3.1-fold (0.50 log units) above it; the whole stated range lies above it.
By their numbers in the retinal dehydrogenase 2 assay, from the lowest: compounds 3 and 1 (each within the scatter of the next); then compound 2.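

In the retinal dehydrogenase 2 assay, replacing pyrimidin-5-yl with pyridin-3-yl gives a 4.3-fold lower number from compound 2 to compound 3 (0.63 log units; beyond the scatter), so at this position a change of one ring atom, with the heavy-atom count unchanged, is enough to shift the read-out beyond the scatter. The other new step, a 2.0-fold lower number from compound 1 to compound 3 (0.30 log units; within the scatter), means that compound 3, with its 1-(pyridin-3-yl)ethyl group, cannot be told apart from compound 1, with its 1-phenylpropyl group. In a physicochemical assay for solubility, using the shake flask method, in phosphate buffer, with a stated time of 24 h, at pH 7.4 (on this read-out lower numbers stand for lower solubility and higher numbers for higher solubility), compound 2 gives 264000 nM and compound 3 gives 209000 nM, two values within the scatter of each other, so the ring change that separates them on inhibition does not separate them on this read-out.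

No measurement shown here explains the shift in inhibition. Still open, from the compounds shown here alone, is how 1-phenylethyl on the sulfur would read, and what an amine on the pyridin-3-yl ring would do.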